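A small swap on a weakly cytotoxic compound

A few compounds are considered here, and "the series" means these few. Any claim that something is new, unique, unknown or untested is made for them only; others in the source may bear on it.

Measured in a functional assay on HepG2 cells (Homo sapiens) for cytotoxicity, read by MTT assay, with a stated time of 72 h; a higher number here means a weaker inhibitor, a lower number a stronger inhibitor:
- Compound 1 `CN1CCN(c2ccc(Nc3ncc4nc(Nc5ccccc5)n(C5CCCCC5)c4n3)cc2)CC1`: > 5000 nM, a limit
- Compound 2 `c1ccc(Nc2ncc3nc(Nc4ccccc4)n(C4CCCC4)c3n2)cc1`: > 5000 nM, a limit
- Compound 3 `Cc1cccc(Nc2nc3cnc(Nc4ccc(N5CCN(C)CC5)cc4)nc3n2C2CCCC2)c1`: 4700 nM

Among the measured compounds shown here, compound 3 gives the only actual number in this assay, at 4700 nM. The other two compounds stand at the limit of > 5000 nM in this assay, at which 2 of the 3 values shown sit.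

Compound 4 `CN1CCN(c2ccc(Nc3ncc4nc(Nc5ccc(Br)cc5F)n(C5CCCC5)c4n3)cc2)CC1` keeps everything in compound 3 except one group, with 4-bromo-2-fluorophenyl in place of 3-methylphenyl on a nitrogen on an aromatic ring.

For the measured compounds named here, no measured pair shows this kind of change, so the only guide is compound 3 at 4700 nM. The expected size of a 1.6-fold lower number from compound 3 to compound 4 (0.19 log units; within the scatter) is none beyond the usual scatter in this assay. For compound 4 the estimated value is 3000 nM, with an expected range of 800 nM to 10000 nM.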

Compound 4, half-maximal inhibitory concentration: > 5000 nM
Compound 4: a limit, no number (the forecaster's own chance of this, stated with the estimate: 40%); middle value at least 1.6-fold (0.22 log units) from the limit.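

With 4-bromo-2-fluorophenyl in place of 3-methylphenyl on this nitrogen, this assay gives an at least 1.0-fold higher number from compound 3 to compound 4 (0.02 log units; that floor lies within the scatter). Compound 4 reads > 5000 nM, which is a limit and not a number. The change therefore brings no sign of a lower number at this position, and the series stays mostly at that limit: the limit of > 5000 nM in this assay, at which 3 of the 4 values shown sit.

From the compounds shown here alone, how far the true value of compound 4 lies past its limit remains open. So does whether an amine or a carboxylic acid on this phenyl ring would bring the number down.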